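Cytotoxicity notes: aryl to benzyl change on the core

A few compounds are considered here, and "the series" means these few. Any claim that something is new, unique, unknown or untested is made for them only; others in the source may bear on it.

Compound 1 `COc1cccc(CNCCCNc2ccnc3cc(-c4ccc(C(F)(F)F)cc4)ccc23)c1O` is measured in an ADME assay on HepG2 cells (Homo sapiens) for cytotoxicity, read by luminescence, CellTiter-Glo and ATP content, with a stated time of 72 h (on this read-out lower numbers stand for an effect already at smaller amounts and higher numbers for an effect only at larger amounts of compound), and gives 2210 nM, the second highest of the three numbers. Compound 2 `FC(F)(F)c1ccc(-c2ccc3c(NCCCNCc4ccco4)ccnc3c2)cc1` gives 3470 nM in this assay, with a 1.6-fold higher number from compound 1 to compound 2 (0.20 log units; within the scatter). Compound 3 `COc1ccc(F)cc1CNCCCNc1ccnc2cc(-c3ccc(F)cc3)ccc12` gives 770 nM; its value and that of compound 1 differ beyond the scatter, with compound 3 lower. Compound 4 `COc1cccc(CNCCCNc2ccnc3cc(Cc4cccc(C(F)(F)F)c4)ccc23)c1O` is not yet measured. It differs from compound 1 by 3-(trifluoromethyl)benzyl in place of 4-(trifluoromethyl)phenyl on an aromatic carbon, on an aromatic carbon of the fused two-ring core. For the measured compounds named here, no measured step touches that position; the one measured step changes the group on the chain carbon and stays within the scatter. No step beyond the scatter is therefore expected, giving an estimated 1.0-fold lower number from compound 1 to compound 4 (0.00 log units; within the scatter). Compound 4 is expected at 2200 nM, within 900 nM to 5400 nM.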

Compound 4, half-maximal effective concentration: 1720 nM
Compound 4: middle estimate off by 1.3-fold (0.11 log units), on the high side; measured number inside the range.
By their numbers in this assay, from the lowest: compound 3; then compounds 4, 1 and 2 (each within the scatter of the next).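

For the compounds shown here, at the aromatic carbon of the shared core, 3-(trifluoromethyl)benzyl in place of 4-(trifluoromethyl)phenyl gives a 1.3-fold lower number from compound 1 to compound 4 (0.11 log units; within the scatter) in this assay, the first reading at this position. This single pair changes both the link to the ring and the place of the trifluoromethyl group, so the two changes cannot be separated. No data on the origin of this result are at hand.

Going by these compounds, whether 4-(trifluoromethyl)benzyl would read differently stays open. So does whether a carboxylic acid or an amine on this ring would give a step beyond the scatter.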